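Swapping the Indole Arm for an Acetylphenyl

The compounds below may be only part of what the source reports. "The series", "measured", "known", "first", "only" and "open" are said of these compounds alone.

Compound 1 `COc1cc(-c2ccnc3cc(-c4c[nH]c5ccccc45)nn23)cc(OC)c1OC` gives the lowest number among the three measured compounds in a functional assay on HCT-116 cells (Homo sapiens) for inhibition, read by CCK-8 assay, with a stated time of 48 h (on this read-out lower numbers stand for stronger inhibition and higher numbers for weaker inhibition), with 35 nM. Compound 2 `COc1cc(-c2ccnc3cc(-c4ccc(N(C)C)cc4)nn23)cc(OC)c1OC` gives 2050 nM and compound 3 `C=Cc1ccc(-c2cc3nccc(-c4cc(OC)c(OC)c(OC)c4)n3n2)cc1` gives 1060 nM in this assay. Replacing the 1H-indol-3-yl of compound 1 by a 4-(dimethylamino)phenyl or a 4-vinylphenyl went with a large loss each time: a 59-fold higher number from compound 1 to compound 2 (1.77 log units; beyond the scatter) and a 30-fold higher number from compound 1 to compound 3 (1.48 log units; beyond the scatter). Between those two phenyl compounds the difference is small, a 1.9-fold lower number from compound 2 to compound 3 (0.29 log units; within the scatter). Compound 4 `COc1cc(-c2ccnc3cc(-c4ccc(C(C)=O)cc4)nn23)cc(OC)c1OC` differs from compound 1 in one place: 4-acetylphenyl in place of 1H-indol-3-yl on an aromatic carbon. Since both earlier changes of this kind were large losses, a large rise in the number is expected for compound 4, estimated as a 43-fold higher number from compound 1 to compound 4 (1.63 log units; beyond the scatter). Compound 4 is therefore expected to give 1500 nM in this assay, with a likely range from 500 nM to 5000 nM.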

Compound 4, half-maximal inhibitory concentration: 4390 nM
The estimate for compound 4 lay 2.9-fold (0.47 log units) below the measured number, within the range that was stated.
By their numbers in this assay, from the lowest: compound 1; then compounds 3 and 2 (each within the scatter of the next); then compound 4.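

In this assay, 4-acetylphenyl brought the largest loss yet at this position (a 130-fold higher number from compound 1 to compound 4 (2.10 log units; beyond the scatter)), so all three phenyl replacements of the 1H-indol-3-yl fell far short of compound 1. The group carried on the phenyl ring also counted, since acetyl was modestly worse than vinyl (a 4.1-fold higher number from compound 3 to compound 4 (0.62 log units; beyond the scatter)) and than dimethylamino (a 2.1-fold higher number from compound 2 to compound 4 (0.33 log units; beyond the scatter)). No measurement shown accounts for these differences.

The compounds leave open whether a carboxylic acid in place of the acetyl, or a phenyl carrying no added group, would stand nearer compound 1 or compound 4.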